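A few compounds are considered here, and "the series" means these few. Any claim that something is new, unique, unknown or untested is made for them only; others in the source may bear on it.

The measured compounds:
Compound 1, `CC1(C)Cc2c(sc(NC(=O)c3cn[nH]c3)c2C(N)=O)C(C)(C)O1`, gives 125 nM in an assay on cells for positive allosteric modulation of Cystic fibrosis transmembrane conductance regulator variant F508del (Homo sapiens), with stated times of 10 min and 7 s, in the presence of a further agent that is not named here; a lower number here means that less compound is needed, a higher number that more compound is needed for the effect.
Compound 2, `CC1(C)Cc2c(sc(NC(=O)C3CCNC3=O)c2C(N)=O)C(C)(C)O1`, gives 101 nM in this assay.
Compound 3, `CC1(C)Cc2c(sc(NC(=O)C3(O)CC3)c2C(N)=O)C(C)(C)O1`, gives 23 nM in this assay.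

Compound 3 holds the lowest of the three numbers in this assay. The two steps leading to it are both beyond the scatter: a 4.4-fold lower number from compound 2 to compound 3 (0.64 log units; beyond the scatter), and, further off, a 5.4-fold lower number from compound 1 to compound 3 (0.74 log units; beyond the scatter). Between the other two compounds the difference is small, a 1.2-fold lower number from compound 1 to compound 2 (0.09 log units; within the scatter), which is within the scatter.

Compound 4, `CC1(C)Cc2c(sc(NC(=O)c3cc(C(F)(F)F)n[nH]3)c2C(N)=O)C(C)(C)O1`, has not been measured. (3-(trifluoromethyl)-1H-pyrazol-5-yl in place of 1-hydroxycyclopropyl on a carbonyl carbon). Of the measured steps, a 5.4-fold lower number from compound 1 to compound 3 (0.74 log units; beyond the scatter) bears on it most: compound 1 likewise carries a pyrazolyl on the carbonyl carbon, so the change from compound 3 to compound 4 largely reverses that step, with a trifluoromethyl on the ring added. a 4.4-fold lower number from compound 2 to compound 3 (0.64 log units; beyond the scatter) points the same way, as it too leaves the 1-hydroxycyclopropyl behind. Going by the values given here, no measured step tells what the trifluoromethyl itself contributes, so the return toward the number of compound 1 is the guide, with wide uncertainty. The step expected is a 4.3-fold higher number from compound 3 to compound 4 (0.64 log units; beyond the scatter). In this assay compound 4 is therefore estimated at 100 nM, within a range from 30 nM to 330 nM.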

Compound 4, half-maximal effective concentration: 3 nM
Beside the measured number, compound 4's estimate is 33-fold (1.52 log units) above it; the measured number lies below the stated range.
By their numbers in this assay, from the lowest: compound 4; then compound 3; then compounds 2 and 1 (each within the scatter of the next).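

In this assay, the place on the carbonyl carbon whose other neighbour is the amide-type nitrogen proves able to carry an aromatic ring with a low number, which compound 1 had not suggested: the change to 3-(trifluoromethyl)-1H-pyrazol-5-yl gives a 7.7-fold lower number from compound 3 to compound 4 (0.88 log units; beyond the scatter) and so shows that 1-hydroxycyclopropyl is not required for the lowest numbers in this set. The largest gain comes against the other pyrazole, with a 42-fold lower number from compound 1 to compound 4 (1.62 log units; beyond the scatter) and a step of similar size against the lactam-bearing compound, a 34-fold lower number from compound 2 to compound 4 (1.53 log units; beyond the scatter) and so the kind of ring at this place, and what it carries, can shift the number widely. Nothing given here accounts for any of these differences.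

The compounds shown do not separate the contribution of the trifluoromethyl from that of the move from 1H-pyrazol-4-yl to 1H-pyrazol-5-yl, so the share of each in the gain remains unknown. Going by these compounds, it also remains open whether a methyl or a chlorine in place of the trifluoromethyl would keep the number of compound 4, or whether the pyrazole itself could give way to a pyridine.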